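Working notes on a cytotoxicity series

The source may hold more compounds than are shown below. What is called first, only, known or untested is meant among the compounds shown, and "the series" means these compounds.

Measured compounds:
compound 1 `Cc1nc(Nc2ccccc2)sc1C(=O)/C=C/c1ccc(Cl)cc1`: > 25000 nM
compound 2 `Cc1ccccc1Nc1nc(C)c(C(=O)/C=C/c2ccc(Cl)cc2)s1`: > 25000 nM
compound 3 `Cc1nc(Nc2ccccc2)sc1C(=O)/C=C/c1ccccc1Cl`: > 25000 nM

In a functional assay on NCI-H460 cells (Homo sapiens) for cytotoxicity, read by MTT assay (a lower number here means a stronger inhibitor, a higher number a weaker inhibitor), compound 1 gives > 25000 nM, which is a limit of the assay and not a number. Compound 2 also gives only a limit in this assay, > 25000 nM. Compound 3 likewise gives a limit, > 25000 nM. The step that the two limits leave unreadable from compound 1 to compound 2 goes with the change (methyl in place of hydrogen on an aromatic carbon). The step that the two limits leave unreadable from compound 1 to compound 3 goes with the change (2-chlorophenyl in place of 4-chlorophenyl on a double-bonded chain carbon bound to a double-bonded chain carbon), so the cores of compound 1 and compound 3 differ only in that way. Neither step can be read, because of the limit of > 25000 nM in this assay, at which 3 of the 3 values shown sit.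

Compound 4 `Cc1ccc(Nc2nc(C)c(C(=O)/C=C/c3ccccc3Cl)s2)cc1` is not yet measured. It differs from compound 3 by methyl in place of hydrogen on an aromatic carbon. This is the same kind of change as from compound 1 to compound 2, not the same: in compound 2 the methyl sits ortho to a large group, in compound 4 it sits para to a large group. The step that the limit leaves unreadable from compound 3 to compound 4 is expected to be small or unreadable, resting on the fact that the comparable step that the two limits leave unreadable from compound 1 to compound 2 could not be read and that compound 3 stands at the limit. Compound 4 is therefore estimated at 30000 nM in this assay, most likely reported as a limit again.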

Compound 4, half-maximal inhibitory concentration: > 25000 nM
Compound 4: only a limit was reported; the forecaster's own chance of this, stated with the estimate: 80%; the middle value does not contradict the limit.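

In this assay compound 4 gives > 25000 nM, again a limit of the assay and not a number, so the step between compound 3 and compound 4 cannot be read, because of this: the limit of > 25000 nM in this assay, at which 4 of the 4 values shown sit.

The compounds shown leave open whether either change, methyl in place of hydrogen or 2-chlorophenyl in place of 4-chlorophenyl, alters cytotoxicity on the shared core at all.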